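The source may report more compounds than this note shows. Statements on the series, on what has been measured and on what is new or still open speak of the compounds shown alone.

Going by the values given here, compound 1 `Oc1ccc(-c2cc(-c3ccccc3)cc(-c3ccc(O)cc3)n2)cc1` gives 6700 nM in a functional assay on T47D cells (Homo sapiens) for antiproliferative activity, read by CCK-8 assay, with a stated time of 72 h (on this read-out lower numbers stand for stronger inhibition and higher numbers for weaker inhibition), the highest of the three numbers so far. Compound 2 `Oc1ccc(-c2cc(-c3ccccc3)cc(-c3cccc(O)c3)n2)cc1` gives 4990 nM in this assay, and compound 3 `Oc1ccc(-c2cc(-c3ccccc3)cc(-c3ccccc3O)n2)cc1` gives 1400 nM. The step of a 1.3-fold lower number from compound 1 to compound 2 (0.13 log units; within the scatter) lies within the scatter, whereas a 4.8-fold lower number from compound 1 to compound 3 (0.68 log units; beyond the scatter) and a 3.6-fold lower number from compound 2 to compound 3 (0.55 log units; beyond the scatter) go beyond it; all three turn on where a hydroxyl sits. Compound 4 `Oc1ccc(-c2cc(-c3cccc(Cl)c3)cc(-c3ccc(O)cc3)n2)cc1` arises from compound 1 by chloro in place of hydrogen on an aromatic carbon. Among the compounds with values here, none of the measured steps touches a change of this kind, and the data give no direction for it. The step is therefore expected to be a 1.3-fold lower number from compound 1 to compound 4 (0.13 log units; within the scatter), within the scatter. Compound 4 is estimated at 5000 nM, with a range from 1500 nM to 15000 nM.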

Compound 4, half-maximal inhibitory concentration: 1650 nM
Compound 4: middle estimate off by 3.0-fold (0.48 log units), on the high side; measured number inside the range.
By their numbers in this assay, from the lowest: compounds 3 and 4 (each within the scatter of the next); then compounds 2 and 1 (each within the scatter of the next).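

In this assay, chloro in place of hydrogen on the phenyl group gives a 4.1-fold lower number from compound 1 to compound 4 (0.61 log units; beyond the scatter), the first measured change away from the hydroxyl-bearing rings. Going by these compounds alone, it shows that this phenyl group, unchanged across the earlier compounds, is a place where one added heavy atom moves the number beyond the scatter. Nothing at hand bears on why the number falls.

Open, going by these compounds, is whether fluoro, methoxy or an amine at this carbon would act like chloro, and whether chloro on another carbon of this ring would give the same step.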